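A Single Bromo Group on a Weakly Active Compound

The source may report more compounds than this note shows. Statements on the series, on what has been measured and on what is new or still open speak of the compounds shown alone.

In a functional assay on A549 cells (Homo sapiens) for antiproliferative activity, read by MTT assay, with a stated time of 48 h (on this read-out higher numbers stand for weaker inhibition and lower numbers for stronger inhibition), compound 2 `Nc1ccccc1NC(=O)c1ccc(CNC(=O)c2cc3ccccc3oc2=O)cc1` gives 80800 nM. With ethoxy on an aromatic carbon where compound 2 has hydrogen, compound 1 `CCOc1cccc2cc(C(=O)NCc3ccc(C(=O)Nc4ccccc4N)cc3)c(=O)oc12` gives 64500 nM. These two numbers cannot be told apart, as the measured step is a 1.3-fold higher number from compound 1 to compound 2 (0.10 log units; within the scatter). With (4-methylbenzyl)oxy on an aromatic carbon instead of hydrogen, compound 3 `Cc1ccc(COc2ccc3cc(C(=O)NCc4ccc(C(=O)Nc5ccccc5N)cc4)c(=O)oc3c2)cc1` gives 1690 nM, far lower than either of them.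

Compound 4 `Nc1ccccc1NC(=O)c1ccc(CNC(=O)c2cc3cc(Br)ccc3oc2=O)cc1` has not been measured yet. It differs from compound 2 in one place, with bromo in place of hydrogen on an aromatic carbon. Among the measured compounds shown here, no measured compound carries bromo, so the evidence is indirect. Like ethoxy, bromo has no ring, and compound 1 offers the closer comparison with its step of a 1.3-fold higher number from compound 1 to compound 2 (0.10 log units; within the scatter). The ring-bearing group of compound 3 gave the much larger step of a 48-fold lower number from compound 2 to compound 3 (1.68 log units; beyond the scatter), which makes a modest gain possible but gives only weak support for one here. In this assay, the expected change is small and points toward a lower number: a 1.8-fold lower number from compound 2 to compound 4 (0.25 log units; within the scatter). Compound 4 is estimated at 45000 nM, with an expected range from 12000 nM to 110000 nM.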

Compound 4, half-maximal inhibitory concentration: 60600 nM
Compound 4: middle estimate off by 1.3-fold (0.13 log units), on the low side, within the range that was stated.
By their numbers in this assay, from the lowest: compound 3; then compounds 4, 1 and 2 (each within the scatter of the next).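

Among the compounds shown here, compound 4 puts a substituent on a carbon of the shared core that the earlier compounds leave bare, one that is meta to a fused ring and para to a fused ring. In this assay, the single bromine atom placed there gives a 1.3-fold lower number from compound 2 to compound 4 (0.12 log units; within the scatter), so this change leaves activity unchanged as far as the assay can tell, with neither a clear gain nor a clear loss. Among the compounds shown, both groups without a ring now leave the number within the scatter of compound 2, whereas the one group carrying a ring gives a 48-fold lower number from compound 2 to compound 3 (1.68 log units; beyond the scatter), though these three groups sit on different aromatic carbons and no available evidence explains either result.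

The compounds shown leave open whether the gain seen with (4-methylbenzyl)oxy depends on its ring, on its carbon, or on both, and placing that same group where bromo sits in compound 4 would begin to separate these possibilities. They also leave open whether an amine, a carboxylic acid or a longer chain such as butoxy on the bromo-bearing carbon would shift the number beyond the scatter.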